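A few compounds are considered here, and "the series" means these few. Any claim that something is new, unique, unknown or untested is made for them only; others in the source may bear on it.

The measured compounds in a functional assay on U2OS cells for antagonist activity at proto-oncogene Wnt-3 (Homo sapiens), read by a luciferase reporter, with a stated time of 18 h; a lower number here means that less compound is needed, a higher number that more compound is needed for the effect:
compound 1, `CN(C)CC(=O)N1CCC(NS(=O)(=O)c2cc(S(=O)(=O)c3ccccc3)ccc2C(F)(F)F)CC1`, gives 280 nM;
compound 2, `O=C(Cn1ccnc1)N1CCC(NS(=O)(=O)c2cc(S(=O)(=O)c3ccccc3)ccc2C(F)(F)F)CC1`, gives 230 nM;
compound 3, `CC(C)(C)OC(=O)N1CCC[C@H]1C(=O)N1CCC(NS(=O)(=O)c2cc(S(=O)(=O)c3ccccc3)ccc2C(F)(F)F)CC1`, gives 60 nM.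

Compound 3 stands at the lowest number of the three. The nearest measured step to it is a 3.8-fold lower number from compound 2 to compound 3 (0.58 log units; beyond the scatter), and a 4.7-fold lower number from compound 1 to compound 3 (0.67 log units; beyond the scatter) is of similar size; the remaining step is a 1.2-fold lower number from compound 1 to compound 2 (0.09 log units; within the scatter). Compound 4, `O=C1CC[C@@H](C(=O)N2CCC(NS(=O)(=O)c3cc(S(=O)(=O)c4ccccc4)ccc3C(F)(F)F)CC2)N1`, is not yet measured. It differs from compound 3 in one place: 5-oxopyrrolidin-2-yl in place of 1-(tert-butoxycarbonyl)pyrrolidin-2-yl on a carbonyl carbon. Both steps into compound 3 bear on this change, since each replaced a group with fewer heavy atoms on that carbonyl carbon by the 1-(tert-butoxycarbonyl)pyrrolidin-2-yl group and gave a modest improvement. Compound 4 keeps the pyrrolidine ring but loses the tert-butoxycarbonyl, so a modest step back in this assay is expected, toward the numbers of compound 1 and compound 2, while the retained ring leaves room for it to stay nearer compound 3. For compound 4 the expected value is 150 nM (range 50 nM to 450 nM), which means an expected step of a 2.5-fold higher number from compound 3 to compound 4 (0.40 log units; beyond the scatter).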

Compound 4, half-maximal effective concentration: 240 nM
Estimate against measurement, compound 4: 1.6-fold (0.20 log units) below, and the stated range covers the measured number.
By their numbers in this assay, from the lowest: compound 3; then compounds 2, 4 and 1 (each within the scatter of the next).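

In this assay, a five-membered ring on this carbonyl carbon did not by itself keep the low number of compound 3: 5-oxopyrrolidin-2-yl in place of 1-(tert-butoxycarbonyl)pyrrolidin-2-yl gave a modest loss (a 4.0-fold higher number from compound 3 to compound 4 (0.60 log units; beyond the scatter)). Compound 4 instead falls level with the two earlier compounds (a 1.0-fold higher number from compound 2 to compound 4 (0.02 log units; within the scatter); a 1.2-fold lower number from compound 1 to compound 4 (0.07 log units; within the scatter)), so among these four compounds the lower number appears only with the 1-(tert-butoxycarbonyl)pyrrolidin-2-yl group. Nothing measured here accounts for this step.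

The change removes the tert-butoxycarbonyl group and adds the ring carbonyl at once, and the compounds shown do not separate the two. Going by these compounds, a plain pyrrolidin-2-yl with a free secondary amine, or one carrying an acetyl group in place of the tert-butoxycarbonyl, remains open at this position.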